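From a Bromophenyl Arm to a Hydroxy-Methylphenyl Arm

The source may hold more compounds than are shown below. What is called first, only, known or untested is meant among the compounds shown, and "the series" means these compounds.

Compound 1 `O=C1Nc2ccc(Br)cc2/C1=N/NC(=S)N/N=C/c1ccc(Br)cc1` is the starting point. In a functional assay on HeLa cells (Homo sapiens) for inhibition, read by MTT assay (a higher number here means a weaker inhibitor, a lower number a stronger inhibitor), compound 1 gives 4680 nM, the highest of the two numbers recorded there; compound 2 `Cc1ccc2c(c1)/C(=N/NC(=S)N/N=C/c1c(F)cccc1Cl)C(=O)N2` gives 1510 nM, a lower figure that lies beyond the scatter. Compound 3 `COc1ccc(/C=N/NC(=S)N/N=C2\C(=O)Nc3ccc(C)cc32)c(OC)c1` is recorded as > 50000 nM, a limit rather than a number, and so stands at the limit of > 50000 nM in this assay, at which 1 of the 3 values shown sits. Compound 4 `Cc1ccc(O)c(/C=N/NC(=S)N/N=C2\C(=O)Nc3ccc(Br)cc32)c1` has not yet been measured. It differs from compound 1 in one place: 2-hydroxy-5-methylphenyl in place of 4-bromophenyl on a carbon with a double bond to nitrogen. Among the measured compounds shown here, no measured pair isolates this change. Compound 4 is expected to give 5500 nM in this assay, with a range from 1500 nM to 20000 nM. That estimate implies a step of a 1.2-fold higher number from compound 1 to compound 4 (0.07 log units; within the scatter), which is expected to stay within the scatter.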

Compound 4, half-maximal inhibitory concentration: > 50000 nM
Compound 4: no number, only a limit; the forecaster's own chance of this, stated with the estimate: 20%; middle value at least 9.0-fold (0.95 log units) away from the limit.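

Among the compounds shown here, the first step between compounds that differ in one place shows that the arm on the carbon with a double bond to nitrogen is not indifferent to change: in this assay, 2-hydroxy-5-methylphenyl in place of 4-bromophenyl gives an at least 10-fold higher number from compound 1 to compound 4 (1.02 log units; beyond the scatter). From the compounds shown here alone, compound 4 reads > 50000 nM, which is a limit, so the full size of the step stays unknown. The limit is shared within this small set: the limit of > 50000 nM in this assay, at which 2 of the 4 values shown sit.

The compounds shown do not separate the hydroxy from the methyl in this change. They also leave open how an amine in place of the hydroxy would read.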